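Chain-length step in the fluorinated isothiocyanate series

The source may report more compounds than this note shows. Statements on the series, on what has been measured and on what is new or still open speak of the compounds shown alone.

Measured so far:
compound 1 `CN(C)C(=O)c1cc2cnc(Nc3ccc(C(=O)NCCCCCCCN=C=S)cc3)nc2n1C1CCCC1`: 75.7%
compound 2 `CN(C)C(=O)c1cc2cnc(Nc3ccc(C(=O)NCCCN=C=S)cc3F)nc2n1C1CCCC1`: 9.27%
compound 3 `CN(C)C(=O)c1cc2cnc(Nc3ccc(C(=O)NCCCCCCN=C=S)cc3F)nc2n1C1CCCC1`: 29.1%

In a functional assay on NCI-H1299 cells (Homo sapiens) for inhibition, read by CCK-8 assay, with a stated time of 72 h, tested at 1 uM (a lower number here means a weaker effect, a higher number a stronger effect of the compound at the concentration tested), compound 3 stands second highest of the three numbers. Among the measured compounds shown here, the step of a number 19.8 percentage points higher from compound 2 to compound 3 (beyond the scatter) lies beyond the scatter and separates it from the lowest value, while compound 1 gives 75.7%, the highest of the three; no single-change step between those two is available, as they differ in both chain and fluorine.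

Compound 4 `CN(C)C(=O)c1cc2cnc(Nc3ccc(C(=O)NCCCCCCCN=C=S)cc3F)nc2n1C1CCCC1` differs from compound 3 by a group of 4 heavy atoms (2 carbon, 1 nitrogen, 1 sulfur; no ring) in place of a group of 3 heavy atoms (1 carbon, 1 nitrogen, 1 sulfur; no ring), on a saturated chain carbon, six bonds along the chain from an amide-type nitrogen. For the measured compounds named here, the only measured step that bears on this is a number 19.8 percentage points higher from compound 2 to compound 3 (beyond the scatter), a lengthening of the same chain; it was modest and upward. The present lengthening is smaller in count, so a smaller upward movement is expected, but possibly within the scatter.

Compound 4 is expected to give 42%, with a range of 22% to 65%. The expected step is a number 12.9 percentage points higher from compound 3 to compound 4 (beyond the scatter).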

Compound 4, a percentage reported as inhibition, at one concentration (the size of the read-out at that concentration, not a potency): -9.23%
Estimate against measurement, compound 4: 51.2 percentage points above; measured number below the stated range.
By their numbers in this assay, from the lowest: compound 4; then compound 2; then compound 3; then compound 1.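

In this assay the rise a number 19.8 percentage points higher from compound 2 to compound 3 (beyond the scatter) does not continue with the further lengthening, which gives a number 38.3 percentage points lower from compound 3 to compound 4 (beyond the scatter) and leaves the longest fluorinated chain under the shortest, with a number 18.5 percentage points lower from compound 2 to compound 4 (beyond the scatter) in this series. At this chain length, fluoro in place of hydrogen on an aromatic carbon goes with a number 84.9 percentage points lower from compound 1 to compound 4 (beyond the scatter) and turns the highest number shown into the lowest. No evidence at hand explains either drop. Open, as far as these compounds go, is whether a longer chain stays this low. Also open, from the compounds shown here alone, is whether chloro in place of fluoro gives a comparable drop.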